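Limits only for compound 4's cytotoxicity step

The compounds below may be only part of what the source reports. "The series", "measured", "known", "first", "only" and "open" are said of these compounds alone.

Measured in an ADME assay on BJ cells (Homo sapiens) for cytotoxicity, with a stated time of 72 h; on this read-out higher numbers stand for an effect only at larger amounts of compound and lower numbers for an effect already at smaller amounts:
- Compound 1 `Nc1nc(-c2ccccn2)nn1-c1ncnc2ccccc12`: limit, > 50000 nM
- Compound 2 `COc1cc2nc(Cl)nc(-n3nc(-c4ccccn4)nc3N)c2cc1OC`: limit, > 13000 nM
- Compound 3 `CCOC(=O)CNc1nc(-n2nc(-c3ccccn3)nc2N)c2cc(OC)c(OC)cc2n1`: limit, > 27000 nM

Each of these entries is a limit, not a number. Compound 3 therefore stands at its limit of > 27000 nM and cannot be ranked against the other two. Compound 4 `COc1cc2nc(C)nc(-n3nc(-c4ccccn4)nc3N)c2cc1OC` differs from it by methyl in place of ((ethoxycarbonyl)methyl)amino on an aromatic carbon. Going by the values given here, the only measured step at this place is a step that the two limits leave unreadable from compound 2 to compound 3, so it offers no size to carry over. No step beyond the scatter is therefore expected in this assay, and another limit is likely. The expected step is a step that the limit leaves unreadable from compound 3 to compound 4. For compound 4 the estimate is 30000 nM, with an expected range of 12000 nM to 60000 nM.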

Compound 4, half-maximal effective concentration: > 13000 nM
Compound 4 was reported as a limit (the forecaster's own chance of this, stated with the estimate: 75%); the middle value does not contradict the limit.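

In this assay compound 4 gives > 13000 nM, which is a limit. Compound 2 and compound 3 are also limits, so neither step to compound 4 can be read. Going by these compounds, whether methyl, chloro or ((ethoxycarbonyl)methyl)amino at this place changes the read-out at all stays open.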